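A Cyclopentyl Group Replaces Thiophen-2-yl

The source may hold more compounds than are shown below. What is called first, only, known or untested is meant among the compounds shown, and "the series" means these compounds.

Compound 1 `CCOc1ccc(C2(c3ccc(O)cc3)C(=O)Nc3c2ccc(F)c3F)cc1` gives 24 nM
Compound 2 `O=C1Nc2c(ccc(F)c2F)C1(c1ccc(O)cc1)c1cccs1` gives 0.3 nM

In a functional assay on PC-3 cells (Homo sapiens) for cytotoxicity, read by WST assay, with a stated time of 72 h (on this read-out higher numbers stand for weaker inhibition and lower numbers for stronger inhibition), compound 2 holds the lower of the two numbers, 0.3 nM, and compound 1 stands higher at 24 nM. Compound 3 `O=C1Nc2c(ccc(F)c2F)C1(c1ccc(O)cc1)C1CCCC1` has not yet been measured. It differs from compound 2 by cyclopentyl in place of thiophen-2-yl on a saturated ring carbon, with cyclopentyl in place of thiophen-2-yl on a saturated ring carbon.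

Among the compounds with values here, only one measured step bears on this place: an 80-fold lower number from compound 1 to compound 2 (1.90 log units; beyond the scatter), a large change beyond the scatter. Within the data shown here, it shows that the group here can matter greatly, but no measured compound carries a non-aromatic ring at this place. With compound 2 at 0.3 nM, a higher number is expected in this assay, probably beyond the scatter yet smaller than that step. The expected change is a 17-fold higher number from compound 2 to compound 3 (1.22 log units; beyond the scatter). For compound 3 the estimated value is 5 nM, within an expected range of 0.6 nM to 40 nM.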

Compound 3, half-maximal inhibitory concentration: 8.2 nM
Compound 3: the middle estimate sits 1.6-fold (0.21 log units) below what was measured; measured number inside the range.
By their numbers in this assay, from the lowest: compound 2; then compound 3; then compound 1.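

In this assay, replacing the aromatic ring with a non-aromatic ring of the same heavy-atom count carries a large cost (a 27-fold higher number from compound 2 to compound 3 (1.44 log units; beyond the scatter)), so the low number does not survive this change at the saturated ring carbon. Yet an aromatic ring alone does not secure a low number here, since the cyclopentyl compound still improves modestly on the 4-ethoxyphenyl compound (a 2.9-fold lower number from compound 1 to compound 3 (0.47 log units; beyond the scatter)). No measurement at hand accounts for either step.

The compounds shown leave open how a smaller ring such as cyclopropyl, an open chain such as isopropyl, or a furan-2-yl ring with oxygen in place of sulfur would compare with thiophen-2-yl. Nor do they separate the sulfur atom of thiophen-2-yl from its aromatic ring as the feature that goes with the lowest number.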